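The source may hold more compounds than are shown below. What is called first, only, known or untested is meant among the compounds shown, and "the series" means these compounds.

Compounds measured so far:

Compound 1, `C/C=C/C(=O)Nc1c(C(O)(C(F)(F)F)C(F)(F)F)ccc2ccccc12`, in a functional assay (Sus scrofa) with sulfonylurea receptors; K-ATP channels (Homo sapiens) as the target (a higher number here means that more compound is needed for the effect, a lower number that less compound is needed), gives 49 nM.
Compound 2, `O=C(Nc1c(C(O)(C(F)(F)F)C(F)(F)F)ccc2ccccc12)c1cccc(Cl)c1`, gives 851 nM.
Compound 3, `O=C(Nc1c(C(O)(C(F)(F)F)C(F)(F)F)ccc2ccccc12)c1cccc([N+](=O)[O-])c1`, gives 427 nM.

Among these three numbers compound 3 stands second highest. Its nearest neighbour is compound 2: the step of a 2.0-fold lower number from compound 2 to compound 3 (0.30 log units; within the scatter) lies within the scatter, so the two cannot be told apart. Its furthest neighbour is compound 1, with an 8.7-fold higher number from compound 1 to compound 3 (0.94 log units; beyond the scatter).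

Compound 4, `O=C(Nc1c(C(O)(C(F)(F)F)C(F)(F)F)ccc2ccccc12)c1ccc(Cl)cc1`, is the next compound for this assay. It differs from compound 3 in one place: 4-chlorophenyl in place of 3-nitrophenyl on a carbonyl carbon.

Two kinds of measured step bear on this change. The step of a 2.0-fold lower number from compound 2 to compound 3 (0.30 log units; within the scatter) shows that swapping chloro for nitro on the aromatic ring, with the ring attachment kept, left the number essentially where it was. The steps of a 17-fold higher number from compound 1 to compound 2 (1.24 log units; beyond the scatter) and an 8.7-fold higher number from compound 1 to compound 3 (0.94 log units; beyond the scatter) show that both aryl amides sit far from the propenyl amide of compound 1. Among the measured compounds shown here, no measured pair moves the substituent to a different position on the ring, so that part of the change is untested. Compound 4 is therefore expected to land close to compounds 2 and 3, with a 1.4-fold higher number from compound 3 to compound 4 (0.15 log units; within the scatter) expected to stay within the scatter. The estimate for compound 4 is 600 nM, with a range from 200 nM to 1800 nM.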

Compound 4, half-maximal effective concentration: 389 nM
Compound 4: the middle estimate sits 1.5-fold (0.19 log units) above what was measured; measured number inside the range.
By their numbers in this assay, from the lowest: compound 1; then compounds 4, 3 and 2 (each within the scatter of the next, the first and the last beyond it).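

In this assay, the pair of compound 2 and compound 4 gives the first view of where the chloro group sits on the aryl amide: 4-chlorophenyl in place of 3-chlorophenyl gives a modest step (a 2.2-fold lower number from compound 2 to compound 4 (0.34 log units; beyond the scatter)) that lies beyond the scatter. Exchanging 3-nitrophenyl for 4-chlorophenyl alters both the substituent and its place on the ring, yet the result (a 1.1-fold lower number from compound 3 to compound 4 (0.04 log units; within the scatter)) leaves the two compounds indistinguishable, while the new aryl amide stays well separated from the propenyl amide (a 7.9-fold higher number from compound 1 to compound 4 (0.90 log units; beyond the scatter)), a larger step than the one between the two chloro compounds. No measurement shown here accounts for any of these steps.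

From the compounds shown here alone, whether a 4-nitrophenyl group would fall with the 3-nitrophenyl group of compound 3 remains open, so the contributions of substituent and ring position to this exchange cannot yet be separated, and an amine or a carboxylic acid on the ring is also unexplored. Going by these compounds, it is equally open whether a longer chain in place of prop-1-en-1-yl would keep the number close to that of compound 1 (49 nM).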